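Swapping One Small Ring for Another on Compound 1

The source may report more compounds than this note shows. Statements on the series, on what has been measured and on what is new or still open speak of the compounds shown alone.

Compound 1 `Cn1nc2c(=O)n(CC3(O)CCN(Cc4ccc(-c5cnco5)cc4Cl)CC3)cnc2c1-c1ccc(CN)cc1` gives 71.6 nM in an assay on isolated protein for inhibition of ubiquitin carboxyl-terminal hydrolase 7 (Homo sapiens), with stated times of 30 min and 2 h; on this read-out higher numbers stand for weaker inhibition and lower numbers for stronger inhibition.
Compound 2 `Cn1nc2c(=O)n(CC3(O)CCN(Cc4ccc(-c5ccco5)cc4Cl)CC3)cnc2c1-c1ccc(CNCCO)cc1` gives 8.2 nM in this assay.
Compound 3 `Cn1nc2c(=O)n(CC3(O)CCN(Cc4ccc(-c5ccco5)cc4Cl)CC3)cnc2c1-c1ccc(Cl)cc1` gives 143 nM in this assay.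

Among these three numbers compound 1 stands second highest: compound 3 sits nearest, within the scatter, while compound 2 lies well below it. Compound 4 `Cn1cc(-c2ccc(CN3CCC(O)(Cn4cnc5c(-c6ccc(CN)cc6)n(C)nc5c4=O)CC3)c(Cl)c2)cn1` differs from compound 1 in one place: 1-methyl-1H-pyrazol-4-yl in place of 1,3-oxazol-5-yl on an aromatic carbon. For the measured compounds named here, the only measured step, a 17-fold higher number from compound 2 to compound 3 (1.24 log units; beyond the scatter), concerns a different position on the other side of the shared core and so says nothing direct about this ring swap. Going by the values given here, with no step bearing on it, compound 4 is expected to stay close to compound 1, the estimated step of a 1.0-fold lower number from compound 1 to compound 4 (0.01 log units; within the scatter) being no larger than the scatter. Compound 4 is therefore estimated at 70 nM in this assay, with a range from 25 nM to 200 nM.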

Compound 4, half-maximal inhibitory concentration: 291 nM
For compound 4 the middle estimate is 4.2-fold (0.62 log units) below the measured one, and the stated range ends below it.
By their numbers in this assay, from the lowest: compound 2; then compounds 1 and 3 (each within the scatter of the next); then compound 4.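

This position is sensitive to which five-membered ring it carries: in this assay, 1-methyl-1H-pyrazol-4-yl in place of 1,3-oxazol-5-yl gives a 4.1-fold higher number from compound 1 to compound 4 (0.61 log units; beyond the scatter), which means weaker inhibition. The two rings match in hydrogen-bond donors, hydrogen-bond acceptors and net charge, so those matching counts alone do not fix the number here. Nothing measured here explains the shift.
Still open is whether an unmethylated pyrazole ring or a pyridine ring at this position would give a lower or a higher number than either ring shown.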